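Removing one methoxy: compound 3 to compound 4

A few compounds are considered here, and "the series" means these few. Any claim that something is new, unique, unknown or untested is made for them only; others in the source may bear on it.

Of the compounds shown here, three have been measured in an ADME assay on RAW264.7 cells (Mus musculus) for cytotoxicity, read by MTT assay, with a stated time of 24 h, tested at 1.25 ug/mL; a lower number here means a stronger effect, a higher number a weaker effect of the compound at the concentration tested. Compound 1 `COc1ccc(CCC(=O)c2cccc(O)c2)c(OC)c1` gives 92.1% in this assay. Compound 2 `COc1ccc(C(=O)CCc2ccc(OC)cc2OC)c(O)c1` gives 97.8% in this assay. Compound 3 `COc1ccc(C(=O)CCc2ccc(OC)c(OC)c2)c(O)c1` gives 91.8% in this assay. All three numbers lie within the usual scatter of one another, so none is separated from the rest; compound 3 has compound 1 as its nearest neighbour and compound 2 as its furthest, both within the scatter. Among the compounds with values here, no pair of measured compounds differs in a single place, so no structural step can be read against a step in number.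

Compound 4 `COc1ccc(CCC(=O)c2ccc(OC)cc2O)cc1` has not been measured. It differs from compound 3 in one place: hydrogen in place of methoxy on an aromatic carbon. Within the data shown here, with the measured numbers clustered in one narrow band and no single-change step to draw on, no movement beyond the scatter is expected from this change. The estimated step is a number 0.2 percentage points higher from compound 3 to compound 4 (within the scatter), none beyond the scatter. Compound 4 is therefore expected to give 92% in this assay, with a range from 80% to 100%.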

Compound 4, a percentage reported as activity, at one concentration (the size of the read-out at that concentration, not a potency): 95.1%
For compound 4 the middle estimate is 3.1 percentage points below the measured one; measured number inside the range.
By their numbers in this assay, from the lowest: compounds 3, 1, 4 and 2 (each within the scatter of the next).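

In this assay the series now has its first single-change steps: the step of a number 3.3 percentage points higher from compound 3 to compound 4 (within the scatter) comes with hydrogen in place of methoxy on an aromatic carbon, ortho to a methoxy group and meta to a large group. The same kind of exchange gives the step of a number 2.7 percentage points lower from compound 2 to compound 4 (within the scatter) as well, so two separate methoxy removals that lead to compound 4 both stay within the scatter, and neither methoxy is shown to be needed for this read-out at the one concentration tested. No measurement at hand bears on why these steps are so small.

As far as these compounds go, whether an amine or a carboxylic acid at this place would also stay within the scatter remains open. Also open, from the compounds shown here alone, is whether the same flat picture would hold at any other concentration.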